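The source may hold more compounds than are shown below. What is called first, only, known or untested is meant among the compounds shown, and "the series" means these compounds.

Working notes on the series.

Of the compounds shown here, two have numbers so far. Compound 1 `O=c1[nH]c(=O)n([C@H]2C[C@H](O)[C@@H](CO)O2)cc1/C=N/O` is a nucleoside bearing a substituent on the six-membered aromatic ring with two nitrogens of its core; in an ADME assay on L1210/0 cells (Mus musculus) for cytotoxicity, with a stated time of 48 h (on this read-out lower numbers stand for stronger inhibition and higher numbers for weaker inhibition), compound 1 gives 15500 nM. Compound 2 `CC(=O)OCCOCn1cnc2c(Cl)nc(I)nc21` is built on a different core and in this assay compound 2 gives 8600 nM. For the measured compounds named here, the two numbers lie within the usual scatter of each other, so nothing can be said of an order between compound 1 and compound 2, and no step between them is available.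

Compound 3 `O=c1[nH]c(=O)n([C@H]2C[C@H](O)[C@@H](CO)O2)cc1C#CCO` keeps the core of compound 1 and changes only the substituent on the aromatic carbon: a group of 4 heavy atoms (3 carbon, 1 oxygen; no ring) in place of a group of 3 heavy atoms (1 carbon, 1 nitrogen, 1 oxygen; no ring), on an aromatic carbon The group that enters, 3-hydroxyprop-1-yn-1-yl, carries a triple bond outside aromatic rings in place of the double bond of the group that leaves.

Going by the values given here, with only two numbers and no steps between related compounds, no direction for this change can be read from the data. Compound 3 is expected to give a number close to that of compound 1, so the step of a 1.6-fold lower number from compound 1 to compound 3 (0.19 log units; within the scatter) is expected to stay within the scatter. For compound 3 the estimate in this assay is 10000 nM, with a range from 2000 nM to 60000 nM.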

Compound 3, half-maximal inhibitory concentration: > 200000 nM
Compound 3: a limit, no number (the forecaster's own chance of this, stated with the estimate: 20%); middle value at least 20-fold (1.30 log units) away from the limit.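

In this assay compound 3 carries a limit of the assay and not a number: the limit of > 200000 nM in this assay, at which 1 of the 3 values shown sits.

This gives the series its first readable step, an at least 12-fold higher number from compound 1 to compound 3 (1.11 log units; beyond the scatter), and it shows that the aromatic carbon of the shared core is not indifferent to the group it carries, with 3-hydroxyprop-1-yn-1-yl standing on the side of weaker inhibition. Going by these compounds, the step marks only a lower bound on the size of the change, so the full distance between the two groups stays unknown.

This single step exchanges the whole group at once, and the data do not separate the contribution of the triple bond from that of the terminal hydroxyl or of the chain length. On these data alone, a saturated 3-hydroxypropyl chain, a 3-aminoprop-1-yn-1-yl group or a carboxylic acid on the same aromatic carbon would each bear on that question, and whether any group at this position can give stronger inhibition than the group of compound 1 also remains open.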